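A few compounds are considered here, and "the series" means these few. Any claim that something is new, unique, unknown or untested is made for them only; others in the source may bear on it.

Working notes on the series. In a functional assay on NCI-H460 cells (Homo sapiens) for inhibition, read by MTT assay, with a stated time of 24 h, tested at 100 ug/mL (a lower number here means less inhibition of growth, a higher number more inhibition of growth at the concentration tested), compound 1 `O=C(O)CCCCC(CCSC(=O)c1ccccc1)SC(=O)c1ccccc1` gives a reading of 72.8% and compound 2 `O=C(CCCCC(S)CCS)Nc1ccc(Cl)cn1` gives 55.8% under the same conditions. Compound 3 `O=C(CCCCC(CCSC(=O)c1ccccc1)SC(=O)c1ccccc1)Nc1ccccc1Cl` is reported as "not active" (no number reported) and has no number, so it cannot be placed numerically against the other two. Compound 4 `O=C(CCCCC(CCSC(=O)c1ccccc1)SC(=O)c1ccccc1)Nc1ccc(Cl)cc1` has the same atoms as compound 3, joined differently (4-chlorophenyl in place of 2-chlorophenyl on an amide-type nitrogen), with 4-chlorophenyl in place of 2-chlorophenyl on an amide-type nitrogen. For the measured compounds named here, no measured pair shows this change, so its size in this assay is uncertain. A modest upward step from the not-active reading is expected, possibly no larger than the scatter, and a second not-active result remains plausible. The estimated value for compound 4 is 30% within an expected range (5% to 65%).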

Compound 4, percent growth inhibition at one concentration: "not active" (no number reported)
No number was reported for compound 4; no gap can be computed for the estimate.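

In this assay compound 3 and compound 4 are both reported as not active without a number, and no step can be read between them. As far as these compounds go, what 2-chlorophenyl versus 4-chlorophenyl on the amide-type nitrogen does to growth inhibition stays open, and no supporting data bear on this result.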